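This account rests on a few compounds, and the source may have more. Where it says the series, first, only, none or still open, it means among the compounds named here.

Measured compounds:
Compound 1 `CC(=O)/C(=N\Nc1ccccc1C(F)(F)F)N(C)c1cccc(Cl)c1`: > 10000 nM
Compound 2 `CC(=O)/C(=N\Nc1ccccc1C)N(C)c1cccc(Cl)c1`: > 10000 nM
Compound 3 `CC(=O)/C(=N\c1ccccc1)NNc1ccccc1C`: 526 nM

In an assay on isolated protein for binding affinity to corticotropin-releasing factor receptor 1 (Homo sapiens) (a higher number here means a weaker inhibitor, a lower number a stronger inhibitor), compound 1 gives > 10000 nM, which is a limit of the assay and not a number. Compound 2 likewise gives > 10000 nM, again a limit. Compound 3 gives 526 nM. The change from compound 2 to compound 1 is trifluoromethyl in place of methyl on an aromatic carbon, and its step, a step that the two limits leave unreadable from compound 2 to compound 1, cannot be read because both values sit at the limit of > 10000 nM in this assay, at which 2 of the 3 values shown sit. How the core of compound 3 differs from that of compound 2 is not broken down here.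

Compound 4 `CC(=O)/C(=N\c1ccccc1)NNc1ccccc1C(F)(F)F` carries the same change, (trifluoromethyl in place of methyl on an aromatic carbon). Within the data shown here, since the only measured instance of this change is unreadable, the step from compound 3 to compound 4 is estimated to be small, a 1.3-fold higher number from compound 3 to compound 4 (0.12 log units; within the scatter), with wide uncertainty. Compound 4 is therefore expected to give about 700 nM, between 200 nM and 3000 nM.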

Compound 4, inhibition constant: 2260 nM
Estimate against measurement, compound 4: 3.2-fold (0.51 log units) below; the measured number falls inside the stated range.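

Among these compounds, on the core of compound 3, in this assay, trifluoromethyl in place of methyl on an aromatic carbon gives a 4.3-fold higher number from compound 3 to compound 4 (0.63 log units; beyond the scatter), a modest step and the only readable instance of this change. The same change on the core of compound 2, which gives compound 1, cannot be read, as both values are limits of the assay and not numbers: the limit of > 10000 nM in this assay, at which 2 of the 4 values shown sit. So the change is seen to raise the number on one core only, and these data do not show whether it does the same on the other core, or by how much.

The compounds shown leave open how a methoxy group or an amine in place of methyl would read on the core of compound 3. They also leave open whether any such group would bring the core of compound 2 to a readable value.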